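This account rests on a few compounds, and the source may have more. Where it says the series, first, only, none or still open, it means among the compounds named here.

Among the compounds with values here, the series shares the core of compound 1 `CCCCCNc1nc(N)c2nc(O)n(Cc3ccccc3)c2n1`, and in a functional assay (spleen, spleen) for activation, with Mus musculus as the target (a lower number here means that less compound is needed, a higher number that more compound is needed for the effect), compound 1 gives 0.1 uM, the only number recorded on this core so far. Compound 2 `Nc1ncnc2c1nc(I)n2Cc1ccccc1` reaches only the limit of this assay, > 10 uM. Compound 3 `Nc1ncnc2c1nc(O)n2-c1ccccc1` likewise stops at the limit, > 10 uM. Compound 1 therefore stands alone with a number, while the other two values are limits (the limit of > 10 uM in this assay, at which 2 of the 3 values shown sit). Within the data shown here, no pair of measured compounds differs in a single place, so no measured step is available to lean on.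

Compound 4 `CCCc1nc(N)c2nc(O)n(Cc3ccccc3)c2n1` is the next compound to be measured in this assay, and it differs from compound 1 by propyl in place of pentylamino on an aromatic carbon. Pentylamino leaves and propyl enters on an aromatic carbon of a six-membered aromatic ring with two nitrogen atoms, between two ring nitrogen atoms and meta to an amino group. Among the measured compounds shown here, nothing among the measured compounds shows what this exchange does, so the expectation for compound 4 rests on compound 1 alone. The step is expected to amount to a 10-fold higher number from compound 1 to compound 4 (1.00 log units; beyond the scatter), running toward a higher concentration that lies beyond the usual scatter and well short of the limit. On that basis compound 4 is estimated at 1 uM, with a range from 0.2 uM to 6 uM.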

Compound 4, minimum effective concentration: 1 uM
Compound 4: the middle estimate sits on the measured number at the digits printed, and the stated range covers the measured number.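

Within the data shown here, the first measured step at this position, an aromatic carbon between two ring nitrogen atoms, shows that in this assay propyl in place of pentylamino gives a 10-fold higher number from compound 1 to compound 4 (1.00 log units; beyond the scatter). The pentylamino group is therefore not required for a measurable effect on the shared core, as the all-carbon propyl chain of compound 4 still gives 1 uM. Compound 2 and compound 3 remain the only compounds shown at a limit: the limit of > 10 uM in this assay, at which 2 of the 4 values shown sit.

This single exchange alters chain length and the attachment to the ring together, leaving open whether pentyl or propylamino at this carbon would fall closer to compound 1 or to compound 4, and thus which of the two changes carries the step. Also open, going by these compounds, is how a simple hydrogen or a butoxy chain at this position would read in this assay, and whether either would remain clear of the limit.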